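The source may report more compounds than this note shows. Statements on the series, on what has been measured and on what is new or still open speak of the compounds shown alone.

The measured compounds:

Compound 1, `Cc1nn(C)c(Oc2ccc(F)cc2F)c1/C=N\CCCCCCOc1cc2oc(=O)cc(C)c2cc1Cl`. In a functional assay on SMMC-7721 cells (Homo sapiens) for antiproliferative activity, read by MTT assay, with a stated time of 72 h (a lower number here means a stronger inhibitor, a higher number a weaker inhibitor), compound 1 gives > 25000 nM, which is a limit of the assay, not a number.
Compound 2, `Cc1nn(C)c(Oc2cccc(Cl)c2)c1/C=N\CCCCCCOc1cc2oc(=O)cc(C)c2cc1Cl`. In this assay compound 2 gives 5260 nM.
Compound 3, `Cc1nn(C)c(Oc2ccccc2Br)c1/C=N\CCCCCCOc1cc2oc(=O)cc(C)c2cc1Cl`. In this assay compound 3 gives 19700 nM.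

Compound 3 thus stands at the higher of the two numbers, a weaker inhibitor than compound 2 by the step of a 3.7-fold higher number from compound 2 to compound 3 (0.57 log units; beyond the scatter); compound 1 contributes only a limit, (the limit of > 25000 nM in this assay, at which 1 of the 3 values shown sits).

Compound 4, `Cc1nn(C)c(Oc2ccc(Br)cc2)c1/C=N\CCCCCCOc1cc2oc(=O)cc(C)c2cc1Cl`, is not yet measured. It differs from compound 3 only at the ring on the oxygen: 4-bromophenyl in place of 2-bromophenyl on an oxygen on an aromatic ring. Within the data shown here, no measured step moves a bromine alone on that ring. The two steps that do change that ring, an at least 4.7-fold lower number from compound 1 to compound 2 (0.67 log units; beyond the scatter) and a 3.7-fold higher number from compound 2 to compound 3 (0.57 log units; beyond the scatter), show that swapping it shifts the number modestly, in either direction. A modest shift is therefore expected for compound 4, with the direction uncertain. Compound 4 is expected to give 12000 nM, between 4000 nM and 30000 nM. That expected step, a 1.6-fold lower number from compound 3 to compound 4 (0.22 log units; within the scatter), is estimated to lie near the edge of the scatter.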

Compound 4, half-maximal inhibitory concentration: 3090 nM
Compound 4: the middle estimate sits 3.9-fold (0.59 log units) above what was measured, and the stated range ends above it.
By their numbers in this assay, from the lowest: compounds 4 and 2 (each within the scatter of the next); then compound 3. At a limit, above all of these: compound 1.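

Moving the bromine alone, with the atoms unchanged, is enough to shift the number: 4-bromophenyl in place of 2-bromophenyl gives a 6.4-fold lower number from compound 3 to compound 4 (0.80 log units; beyond the scatter), so where the halogen sits on this ring matters, not only whether one is there. Set against 3-chlorophenyl, 4-bromophenyl gives a 1.7-fold lower number from compound 2 to compound 4 (0.23 log units; within the scatter), so these two rings cannot be told apart in this assay. The step to 4-bromophenyl from 2,4-difluorophenyl, an at least 8.0-fold lower number from compound 1 to compound 4 (0.90 log units; beyond the scatter), starts from a limit for compound 1, not a number: the limit of > 25000 nM in this assay, at which 1 of the 4 values shown sits.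

The compounds shown leave open whether a ring carrying a methoxy or a nitrile, or a plain phenyl, would fall in the same range. They also leave open how 4-chlorophenyl would compare with 4-bromophenyl, and what a shorter chain would do.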